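The source may hold more compounds than are shown below. What is called first, only, known or untested is meant among the compounds shown, and "the series" means these compounds.

In an ADME assay on MT4 cells (Homo sapiens) for cytotoxicity, read by XTT assay, with a stated time of 5 days (on this read-out higher numbers stand for lower toxicity in this test and lower numbers for higher toxicity in this test), compound 1 `C=CCNC(=O)[C@@H](NC(=O)[C@@](O)(CCCN(Cc1ccc(Br)cc1)NC(=O)[C@@H](NC(=O)OC)C(C)(C)C)Cc1ccc(Br)cc1)C(C)C` gives 22000 nM and compound 3 `C=CCNC(=O)[C@@H](NC(=O)[C@@](O)(CCCN(Cc1ccc(Br)cc1)NC(=O)[C@@H](NC(=O)OC)C(C)(C)C)Cc1ccc(Br)cc1)C(C)(C)C` gives 29000 nM. Compound 2 `C=CCNC(=O)[C@@H](NC(=O)[C@@](O)(CCCN(Cc1ccc(Br)cc1)NC(=O)[C@@H](NC(=O)OC)C(C)(C)C)Cc1ccc(CC=C)cc1)C(C)(C)C` stands at > 50000 nM, which is a limit of the assay and not a number. Compound 4 `C=CCNC(=O)[C@@H](NC(=O)[C@@](O)(CCCN(Cc1ccc(Br)cc1)NC(=O)[C@@H](NC(=O)OC)C(C)(C)C)Cc1ccc(CC=C)cc1)C(C)C` departs from compound 2 by hydrogen in place of methyl on a saturated chain carbon bound to three saturated chain carbons, with hydrogen in place of methyl on a saturated chain carbon bound to three saturated chain carbons. The reverse change, methyl in place of hydrogen, gave a 1.3-fold higher number from compound 1 to compound 3 (0.12 log units; within the scatter). Bromo in place of allyl gave an at least 1.7-fold lower number from compound 2 to compound 3 (0.23 log units; that floor lies within the scatter), but compound 4 keeps the allyl group, so that step bears only on where compound 2 stands. In this assay the expected step is an at least 1.2-fold lower number from compound 2 to compound 4 (0.09 log units; that floor lies within the scatter), with none expected beyond the scatter. For compound 4 the estimate is 40000 nM, with an expected range of 20000 nM to 70000 nM.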

Compound 4, half-maximal cytotoxic concentration: 24000 nM
Estimate against measurement, compound 4: 1.7-fold (0.22 log units) above; low and high end bracket the measured number.
By their numbers in this assay, from the lowest: compounds 1, 4 and 3 (each within the scatter of the next). At a limit, above all of these: compound 2.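

In this assay tert-butyl to isopropyl now gives a step beyond the scatter (an at least 2.0-fold lower number from compound 2 to compound 4 (0.31 log units; beyond the scatter)), whereas the same change on the other core stayed within it: (the same change on two cores in this assay, a 1.3-fold higher number (0.12 log units; within the scatter) from compound 1 to compound 3 and an at least 2.0-fold higher number (0.31 log units; beyond the scatter) from compound 4 to compound 2; the limit leaves it open whether they differ). Compound 2 stands at > 50000 nM which is a limit and not a number. With isopropyl in place, allyl in place of bromo on an aromatic carbon stays within the scatter (a 1.1-fold higher number from compound 1 to compound 4 (0.04 log units; within the scatter)).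

As far as these compounds go, how far compound 2 truly lies from compound 4 remains open. Also open, from the compounds shown here alone, is whether a cyclopropyl group at the tert-butyl place or an amine on that aromatic carbon would keep the number in this range.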